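A few compounds are considered here, and "the series" means these few. Any claim that something is new, unique, unknown or untested is made for them only; others in the source may bear on it.

Measured so far in an in vitro ADME assay on microsomes from liver (Mus musculus) for pharmacokinetics, read by LC-MS, with a stated time of 10 min, tested at 1 uM; on this read-out higher numbers stand for fast clearance and lower numbers for slow clearance:
compound 1 `CN1C[C@H](C(=O)Nc2ccc(F)c(F)c2)[C@@H](c2ccc(/C=C/C(=O)Nc3ccccc3N)cc2)C1`: 46 mL/min/kg
compound 2 `CN1C[C@H](C(=O)Nc2ccc(F)c(Cl)c2)[C@@H](c2ccc(/C=C/C(=O)Nc3ccccc3N)cc2)C1`: 34 mL/min/kg

Within the data shown here, compound 2 has the lower of the two numbers, yet the only measured step, a 1.4-fold lower number from compound 1 to compound 2 (0.13 log units; within the scatter), lies within the scatter, so no order between compound 1 and compound 2 is claimed.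

Compound 3 `CN1C[C@H](C(=O)N2CCCCC2)[C@@H](c2ccc(/C=C/C(=O)Nc3ccccc3N)cc2)C1` differs from compound 2 by piperidin-1-yl in place of (3-chloro-4-fluorophenyl)amino on a carbonyl carbon. The measured step of a 1.4-fold lower number from compound 1 to compound 2 (0.13 log units; within the scatter) concerns a different change and gives no direct guide to this one; no step beyond the scatter is expected. Compound 3 is therefore estimated at 38 mL/min/kg (range 19 mL/min/kg to 76 mL/min/kg), an expected step of a 1.1-fold higher number from compound 2 to compound 3 (0.05 log units; within the scatter).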

Compound 3, clearance: 42 mL/min/kg
Compound 3: the middle estimate sits 1.1-fold (0.04 log units) below what was measured; low and high end bracket the measured number.
By their numbers in this assay, from the lowest: compounds 2, 3 and 1 (each within the scatter of the next).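

In this assay, piperidin-1-yl on the carbonyl carbon in place of (3-chloro-4-fluorophenyl)amino gives a 1.2-fold higher number from compound 2 to compound 3 (0.09 log units; within the scatter), and in place of (3,4-difluorophenyl)amino gives a 1.1-fold lower number from compound 1 to compound 3 (0.04 log units; within the scatter). This place therefore tolerates loss of the aromatic ring and the amide hydrogen with the clearance number staying within the scatter, a far larger structural change than the earlier swap of one halogen. No available data speak to the reason for this result.

Open is whether morpholin-4-yl or dimethylamino on this carbonyl carbon would stay within the scatter of these compounds. Also open, as far as these compounds go, is whether any group at this place moves the number beyond it.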